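The source may hold more compounds than are shown below. What is called first, only, known or untested is meant among the compounds shown, and "the series" means these compounds.

In an assay on microsomes from brain for inhibition of Fatty-acid amide hydrolase 1 (Rattus norvegicus), read by fluorescence and HPLC, with a stated time of 60 min (a lower number here means a stronger inhibitor, a higher number a weaker inhibitor), compound 1 `CCCCCCCCc1ccc(OCC(=O)Cn2nnc(-c3ccc(Cl)cc3)n2)cc1` gives 35 nM, and compound 2 `CCCCCCCCc1ccc(OCC(=O)Cn2nnc(Cc3ccccc3)n2)cc1` gives 66 nM; the change from one to the other, a 1.9-fold higher number from compound 1 to compound 2 (0.28 log units; within the scatter), leaves the two compounds within the scatter of each other, so compound 2 stands alongside compound 1 rather than apart from it. Compound 3 `CCCCCCCCc1ccc(OCC(=O)Cn2nnc(-c3ccc(C(=O)O)cc3)n2)cc1` differs from compound 2 by 4-carboxyphenyl in place of benzyl on an aromatic carbon. Among the compounds with values here, only that single step bears on the change, and it did not go beyond the scatter; no measured compound carries a 4-carboxyphenyl group. For compound 3 the expectation is a modest shift, a 1.4-fold higher number from compound 2 to compound 3 (0.13 log units; within the scatter), in this assay. Compound 3 is therefore estimated at 90 nM, with a range from 25 nM to 320 nM.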

Compound 3, half-maximal inhibitory concentration: 90 nM
Estimate against measurement, compound 3: no gap at the digits printed; the measured number falls inside the stated range.
By their numbers in this assay, from the lowest: compounds 1, 2 and 3 (each within the scatter of the next, the first and the last beyond it).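

In this assay, within the data shown here, a carboxylic acid on the aromatic ring is tolerated to a degree that the earlier compounds could not show: 4-carboxyphenyl in place of benzyl stays within the scatter (a 1.4-fold higher number from compound 2 to compound 3 (0.13 log units; within the scatter)). Carboxy in place of chloro on an aromatic carbon gives the first step here beyond the scatter, though a modest one (a 2.6-fold higher number from compound 1 to compound 3 (0.41 log units; beyond the scatter)). No measurement offered here accounts for this step. Going by these compounds, whether an amine or a methyl ester in place of the carboxy group would stand with compound 3 or with compound 1 remains open.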